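The source may hold more compounds than are shown below. What is called first, only, known or untested is meant among the compounds shown, and "the series" means these compounds.

Two compounds of this series have numbers in a functional assay on MCF7 cells (Homo sapiens) for cytotoxicity, read by sulforhodamine B assay; a higher number here means a weaker inhibitor, a lower number a stronger inhibitor. Compound 1 `C=C1[C@@H](OC(C)=O)C[C@@H]2[C@](C)(COC=O)[C@H](OC(C)=O)CC[C@@]2(C)[C@@H]1C[C@@H](Nc1ccc(O)cc1)C1=CCOC1=O` gives 18100 nM, the higher of the two. Compound 2 `C=C1[C@@H](C/C=C2/C(=O)OC[C@H]2OC(C)=O)[C@]2(C)CC[C@@H](OC(C)=O)[C@@](C)(CO[Si](C)(C)C(C)(C)C)[C@H]2C[C@@H]1O` gives 6960 nM, so compound 1 is the weaker inhibitor of the pair by a gap beyond the usual scatter. Compound 3 `C=C1[C@@H](OC(C)=O)C[C@@H]2[C@](C)(COC=O)[C@H](OC(C)=O)CC[C@@]2(C)[C@@H]1C[C@@H](Nc1ccc(C(=O)O)cc1)C1=CCOC1=O` is not yet measured and differs from compound 1 in one place: carboxy in place of hydroxy on an aromatic carbon. Going by the values given here, no measured pair shows how this change acts here, so the expected step is a 1.1-fold higher number from compound 1 to compound 3 (0.04 log units; within the scatter), within the scatter and without a set direction. Compound 3 is estimated at 20000 nM in this assay, with a range from 8000 nM to 50000 nM.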

Compound 3, half-maximal inhibitory concentration: 41700 nM
Beside the measured number, compound 3's estimate is 2.1-fold (0.32 log units) below it; measured number inside the range.
By their numbers in this assay, from the lowest: compound 2; then compound 1; then compound 3.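

With the aromatic carbon para to a large group as the site, carboxy in place of hydroxy gives a 2.3-fold higher number from compound 1 to compound 3 (0.36 log units; beyond the scatter) in this assay. Going by these compounds alone, this is the first one-place comparison, and it places hydroxy ahead of carboxy at this position, by a modest step. No measurement at hand accounts for the step. Open, as far as these compounds go, is how an amine, a methoxy group or a methyl ester would read on the same aromatic carbon. Also open, from the compounds shown here alone, is how the ring would read with hydrogen there in place of any such group.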